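Adding a Hydroxymethyl to Compound 2

A few compounds are considered here, and "the series" means these few. Any claim that something is new, unique, unknown or untested is made for them only; others in the source may bear on it.

In a functional assay on MCF7 cells (Homo sapiens) for inhibition (on this read-out higher numbers stand for weaker inhibition and lower numbers for stronger inhibition), compound 1 (`CCCCCCCCCCCCCCCC(=O)C[C@H](COP(=O)(O)O[C@H]1[C@@H](O)[C@@H](O)[C@H](O)C[C@H]1O)C(=O)CCCCCCCCCCCCCCC`) gives 10000 nM and compound 2 (`CCCCCCCCCCCCCCCCCCOC[C@H](COP(=O)(O)O[C@H]1[C@@H](O)[C@@H](O)[C@H](O)C[C@H]1O)OC`) gives 7200 nM, so these two stand level within the scatter. Compound 3 (`CCCCCCCCCCCCCCCCCCOC[C@H](COP(=O)(O)O[C@@H]1[C@H](O)[C@@H](CO)[C@@H](O)[C@H](O)[C@@H]1O)OC`) differs from compound 2 by hydroxymethyl in place of hydrogen on a saturated ring carbon, with hydroxymethyl in place of hydrogen on a saturated ring carbon. Among the compounds with values here, no measured step shows the effect of this change, so no shift beyond the scatter is expected in this assay. The estimated step of a 1.1-fold lower number from compound 2 to compound 3 (0.04 log units; within the scatter) is accordingly small. Compound 3 is estimated at 6500 nM, with an expected range of 2500 nM to 15000 nM.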

Compound 3, half-maximal inhibitory concentration: 5000 nM
Compound 3: the middle estimate sits 1.3-fold (0.11 log units) above what was measured, and the stated range covers the measured number.
By their numbers in this assay, from the lowest: compounds 3, 2 and 1 (each within the scatter of the next).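

In this assay, placing a hydroxymethyl on this saturated ring carbon, next to two ring atoms that each bear a hydroxy group, gives a 1.4-fold lower number from compound 2 to compound 3 (0.16 log units; within the scatter) and so produces no shift beyond the scatter. This single step shows that the position accepts the hydroxymethyl with the number staying level. No measurement shown here explains this result.

As far as these compounds go, whether an amine or a carboxylic acid in place of the hydroxymethyl on this ring carbon would move the number beyond the scatter stays open. So does the effect of the same hydroxymethyl on the core of compound 1.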